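Nitrooxyethyl Ester in Place of Cyclopropyl on a Shared Core

The compounds below may be only part of what the source reports. "The series", "measured", "known", "first", "only" and "open" are said of these compounds alone.

Three esters built on one shared core have been measured in an ADME assay on a cell-free system (plasma, Homo sapiens) for metabolic stability, with Plasma (Rattus norvegicus) as the target, read by HPLC, at pH 7.4; on this read-out lower numbers stand for a shorter-lived compound and higher numbers for a longer-lived compound. Compound 1 `CC(=O)Oc1ccccc1C(=O)O[C@H]1CO[C@H]2[C@@H]1OC[C@H]2OC(=O)c1snnc1C` gives 0.0642 h. Compound 2 `CC(=O)Oc1ccccc1C(=O)O[C@H]1CO[C@H]2[C@@H]1OC[C@H]2OC(=O)C1CC1` gives 0.0322 h. Compound 3 `COc1ccc(C(=O)O[C@@H]2CO[C@H]3[C@@H]2OC[C@@H]3OC(=O)c2ccccc2OC(C)=O)cc1` gives 0.0525 h. Compound 2 is not set apart from either companion: the steps of a 2.0-fold lower number from compound 1 to compound 2 (0.30 log units; within the scatter) and a 1.6-fold higher number from compound 2 to compound 3 (0.21 log units; within the scatter) both lie within the scatter, and so does a 1.2-fold lower number from compound 1 to compound 3 (0.09 log units; within the scatter), so the three numbers cannot be ranked against one another.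

Compound 4 `CC(=O)Oc1ccccc1C(=O)O[C@H]1CO[C@H]2[C@@H]1OC[C@H]2OC(=O)CCO[N+](=O)[O-]` differs from compound 2 by 2-(nitrooxy)ethyl in place of cyclopropyl on a carbonyl carbon. Within the data shown here, the steps that bear on this change are those made at the same carbonyl carbon: a 2.0-fold lower number from compound 1 to compound 2 (0.30 log units; within the scatter) and a 1.6-fold higher number from compound 2 to compound 3 (0.21 log units; within the scatter), together with a 1.2-fold lower number from compound 1 to compound 3 (0.09 log units; within the scatter). Three different groups at that position gave no separation beyond the scatter, so a fourth group there is expected to behave alike, and the step from compound 2 to compound 4 is estimated as a 1.2-fold higher number from compound 2 to compound 4 (0.09 log units; within the scatter). Compound 4 is therefore expected to give about 0.04 h in this assay, with a range from 0.02 h to 0.09 h.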

Compound 4, half-life: 0.065 h
Estimate against measurement, compound 4: 1.6-fold (0.21 log units) below, within the range that was stated.
By their numbers in this assay, from the lowest: compounds 2, 3, 1 and 4 (each within the scatter of the next, the first and the last beyond it).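

The carbonyl carbon now shows a separation: in this assay, 2-(nitrooxy)ethyl in place of cyclopropyl gives a 2.0-fold higher number from compound 2 to compound 4 (0.31 log units; beyond the scatter), a modest step and the first at this position that lies beyond the scatter. That separation holds only against the cyclopropyl ester, since a 1.2-fold higher number from compound 3 to compound 4 (0.09 log units; within the scatter) and a 1.0-fold higher number from compound 1 to compound 4 (0.01 log units; within the scatter) both stay within the scatter, so the chain is not set apart from 4-methoxyphenyl or 4-methyl-1,2,3-thiadiazol-5-yl. Nothing available here accounts for this step.

On these data alone, what a plain ethyl group, a hydroxyethyl group or a longer nitrooxy-bearing chain would give at this carbonyl carbon remains open, and with it whether the step belongs to the nitrooxy group or to the chain that carries it. Also open, as far as these compounds go, is how a chain ending in an amine or a carboxylic acid would read at the same place.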